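A few compounds are considered here, and "the series" means these few. Any claim that something is new, unique, unknown or untested is made for them only; others in the source may bear on it.

Measured so far:
- compound 1 `CC1(C)Oc2cc(NS(=O)(=O)C3CCCCC3)ccc2NC1=O`: 7040 nM
- compound 2 `CC1(C)Oc2cc(NS(=O)(=O)c3ccc(F)cc3Cl)ccc2NC1=O`: 7160 nM

In a functional assay on LNCaP C4-2B cells (Homo sapiens) for antiproliferative activity, read by luminescence, with a stated time of 96 h (on this read-out higher numbers stand for weaker inhibition and lower numbers for stronger inhibition), compound 1 gives 7040 nM and compound 2 gives 7160 nM. The two share the same core and differ only in the group attached to the sulfonyl sulfur. Compound 2 does not stand apart from compound 1: the step of a 1.0-fold higher number from compound 1 to compound 2 (0.01 log units; within the scatter) lies within the usual scatter, so the two numbers cannot be told apart with confidence.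

Compound 3 `CC1(C)Oc2cc(NS(=O)(=O)c3ccccc3)ccc2NC1=O` is the next member of this short series. Its change from compound 2 is phenyl in place of 2-chloro-4-fluorophenyl on a sulfonyl sulfur. Among the compounds with values here, the only measured step that bears on this position is a 1.0-fold higher number from compound 1 to compound 2 (0.01 log units; within the scatter), where a swap of the whole group on the sulfonyl sulfur left the number essentially unchanged. On that basis, a step of about a 1.0-fold higher number from compound 2 to compound 3 (0.02 log units; within the scatter) is expected for compound 3, that is, no change beyond the scatter in either direction. The estimate for compound 3 in this assay is 7500 nM, with a range from 3000 nM to 20000 nM.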

Compound 3, half-maximal inhibitory concentration: 13300 nM
Estimate against measurement, compound 3: 1.8-fold (0.25 log units) below; measured number inside the range.
By their numbers in this assay, from the lowest: compounds 1, 2 and 3 (each within the scatter of the next).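

In this assay, taking the chlorine and the fluorine off the ring, so that plain phenyl stands on the sulfonyl sulfur in place of 2-chloro-4-fluorophenyl, gives a 1.9-fold higher number from compound 2 to compound 3 (0.27 log units; within the scatter) and so stays within the usual scatter, as does the swap of cyclohexyl for phenyl at the same place, which gives a 1.9-fold higher number from compound 1 to compound 3 (0.28 log units; within the scatter) as its step. Together with the earlier step, this means that three different groups on the sulfonyl sulfur, one of them a carbon ring that is not aromatic and two of them aromatic, cannot be told apart by this read-out, and that the two halogens on the ring make no difference that can be read with confidence. Nothing measured here speaks to why the numbers fall where they do.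

On these data alone, all three groups are six-membered carbon rings, so it remains open whether an amine, a carboxylic acid or a longer alkyl chain on the sulfonyl sulfur would shift the number beyond the scatter. The compounds shown also leave open how far changes to the shared core, which is the same in all three, would matter.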